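The source may hold more compounds than are shown below. What is called first, only, known or untested is meant among the compounds shown, and "the series" means these compounds.

Measured compounds:
- Compound 1, `CC(C)Cc1cc(CNS(=O)(=O)c2cccc3ccccc23)nn1-c1ccccc1`: 2430 nM
- Compound 2, `CC(C)Cc1cc(CNS(=O)(=O)c2ccccc2)nn1-c1ccccc1`: "not determined" (no result reported)
- Compound 3, `CC(C)Cc1cc(CNS(=O)(=O)c2ccc3ccccc3c2)nn1-c1ccccc1`: 3300 nM

In a functional assay on HeLa cells for antagonist activity at 5-hydroxytryptamine receptor 6 (Homo sapiens), read by HTRF and cAMP accumulation, with stated times of 10 min and 30 min (on this read-out lower numbers stand for stronger inhibition and higher numbers for weaker inhibition), compound 3 gives 3300 nM, the higher of the two numbers that exist, while compound 1 gives 2430 nM; the gap between them is a 1.4-fold higher number from compound 1 to compound 3 (0.13 log units; within the scatter), so the two sit together within the usual scatter. Compound 2 carries no result in this assay.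

Compound 4, `CC(C)Cc1cc(CNS(=O)(=O)c2c(Cl)cccc2Cl)nn1-c1ccccc1`, differs from compound 3 in one place: 2,6-dichlorophenyl in place of naphthalen-2-yl on a sulfonyl sulfur. Among the measured compounds shown here, the only measured step that touches the same place, the sulfonyl sulfur, is a 1.4-fold higher number from compound 1 to compound 3 (0.13 log units; within the scatter), and it shows that swapping one naphthalenyl for the other changed nothing beyond the scatter. For the measured compounds named here, no measured pair shows what happens when the two-ring group gives way to a single ring carrying two chlorines, so the expectation rests on that one step alone. Compound 4 is therefore expected to stay near compound 3, with the step of a 1.2-fold higher number from compound 3 to compound 4 (0.08 log units; within the scatter) estimated to lie within or just beyond the scatter. The estimated value for compound 4 in this assay is 4000 nM, with a range from 1500 nM to 12000 nM.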

Compound 4, half-maximal inhibitory concentration: 5650 nM
Compound 4: middle estimate off by 1.4-fold (0.15 log units), on the low side, and the stated range covers the measured number.
By their numbers in this assay, from the lowest: compounds 1, 3 and 4 (each within the scatter of the next, the first and the last beyond it).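

Among the compounds shown here, until now, the only comparison on the sulfonyl sulfur was between two naphthalenyl groups; compound 4 adds a group with one aromatic ring rather than two, carrying two chlorines. In this assay, the change from naphthalen-2-yl stays within the scatter (a 1.7-fold higher number from compound 3 to compound 4 (0.23 log units; within the scatter)), while the change from naphthalen-1-yl goes modestly beyond it (a 2.3-fold higher number from compound 1 to compound 4 (0.37 log units; beyond the scatter)), so a single dichlorinated ring is compared here with two-ring groups without a large shift in either step. No measurement shown explains these steps.

On these data alone, compound 2, with its plain phenyl group, has no result, so steps involving it cannot be read and the contribution of the two chlorines stays unknown. Also open, as far as these compounds go, is how an amine or a carboxylic acid in place of the aromatic ring on the sulfonyl sulfur would behave.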